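The source may report more compounds than this note shows. Statements on the series, on what has been measured and on what is new or still open speak of the compounds shown alone.

Measured compounds in a functional assay on the whole organism (strain Swiss albino) for inhibition, with Mus musculus as the target, in the writhing test, with stated times of 60 min and 15 min, at a dose of 100 mg/kg by the oral route; on this read-out lower numbers stand for less inhibition and higher numbers for more inhibition at the one dose given (going by the name of the read-out):
compound 1 `CCN(CC)C(=O)CC1CCc2cc(OC)c(OC)cc21` gives 27.4%
compound 2 `CCCNC(=O)CC1CCc2cc(OC)c(OC)cc21` gives 26.9%
compound 3 `COc1cc2c(cc1OC)C(CC(=O)NC(C)C)CC2` gives 29.3%

All three share one core and differ only in the group on the amide nitrogen. Compound 2 shows the lowest of the three numbers, but every gap is small: a number 0.5 percentage points lower from compound 1 to compound 2 (within the scatter) and a number 2.4 percentage points higher from compound 2 to compound 3 (within the scatter) both fall within the usual scatter, and so does a number 1.9 percentage points higher from compound 1 to compound 3 (within the scatter). On these numbers no one of the three can be set apart from the others.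

Compound 4 `CCCCCNC(=O)CC1CCc2cc(OC)c(OC)cc21` is the next member. Its difference from compound 2 is ethyl in place of hydrogen on a saturated chain carbon, three bonds along the chain from an amide-type nitrogen. Within the data shown here, none of the measured steps makes exactly this change; the nearest is the branching exchange on the amide nitrogen seen in a number 2.4 percentage points higher from compound 2 to compound 3 (within the scatter), and the swap of the whole amine piece in a number 0.5 percentage points lower from compound 1 to compound 2 (within the scatter) is likewise flat. All changes tried so far on this part of the molecule have left the read-out essentially unchanged, so the expectation for compound 4 in this assay is a step of no more than the scatter, with no direction favoured.

Compound 4 is therefore expected to give about 28% in this assay, with a range of 18% to 38%. This expected result corresponds to a step of a number 1.1 percentage points higher from compound 2 to compound 4 (within the scatter).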

Compound 4, a percentage reported as inhibition, in the whole organism at one dose (the size of the read-out at that dose, not a potency): 71.7%
For compound 4 the middle estimate is 43.7 percentage points below the measured one; the whole stated range lies below it.
By their numbers in this assay, from the lowest: compounds 2, 1 and 3 (each within the scatter of the next); then compound 4.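

The amide nitrogen substituent is not a silent position in this assay: the flat picture among the propyl, isopropyl and diethylamino amides does not extend to pentyl, with a number 44.8 percentage points higher from compound 2 to compound 4 (beyond the scatter) for ethyl in place of hydrogen on a saturated chain carbon, three bonds along the chain from an amide-type nitrogen. The pentyl amide also stands apart from the other two earlier compounds, with a number 42.4 percentage points higher from compound 3 to compound 4 (beyond the scatter) and a number 44.3 percentage points higher from compound 1 to compound 4 (beyond the scatter), so the change in the read-out appears only with this chain and not with the smaller groups. No measurement in hand bears on why the pentyl chain gives this result.

The compounds shown leave open how the read-out follows chain length, since a butyl group and a longer chain such as heptyl on the amide nitrogen would show whether the number rises gradually, keeps climbing or falls back. Also open, from the compounds shown here alone, is whether a branched pentyl group, or a pentyl chain ending in an amine or a carboxylic acid, would keep the read-out of compound 4.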